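The source may hold more compounds than are shown below. What is called first, only, known or untested is meant among the compounds shown, and "the series" means these compounds.

Notes on the series. Compound 2 `Cc1ccccc1C(=O)Nc1sc2c(c1C(N)=O)CCN(C(=S)Nc1ccccc1Cl)C2` in a functional assay on HL-60 cells (Homo sapiens) for antiproliferative activity, with a stated time of 24 h (on this read-out lower numbers stand for stronger inhibition and higher numbers for weaker inhibition), gives 20900 nM, the higher of the two numbers recorded so far. Compound 1 `NC(=O)c1c(NC(=O)c2ccccc2I)sc2c1CCN(C(=S)Nc1ccccc1Cl)C2` in this assay gives 8560 nM; the two are separated by the step of a 2.4-fold higher number from compound 1 to compound 2 (0.39 log units; beyond the scatter). Compound 3 `NC(=O)c1c(NC(=O)c2ccc(C(F)(F)F)cc2)sc2c1CCN(C(=S)Nc1ccccc1Cl)C2` has not been measured. The change from compound 2 to compound 3 is 4-(trifluoromethyl)phenyl in place of 2-methylphenyl on a carbonyl carbon. Going by the values given here, the one measured step, a 2.4-fold higher number from compound 1 to compound 2 (0.39 log units; beyond the scatter), swaps a single substituent on the amide-linked aryl ring and moved the number by a modest amount; the change to compound 3 removes the 2-methylphenyl altogether and brings in a differently substituted ring, and no measured pair isolates that exchange. Since the single aryl variation seen so far shifted the read-out only modestly, a step of similar or somewhat larger size is expected, with the direction uncertain and a slight lean toward a lower number given that compound 1 at 8560 nM sits below compound 2. Compound 3 is therefore expected to give about 12000 nM in this assay, within 4000 nM to 40000 nM. The expected step is a 1.7-fold lower number from compound 2 to compound 3 (0.24 log units; within the scatter).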

Compound 3, half-maximal inhibitory concentration: 36100 nM
Compound 3: the middle estimate sits 3.0-fold (0.48 log units) below what was measured; the range from low to high includes it.
By their numbers in this assay, from the lowest: compound 1; then compounds 2 and 3 (each within the scatter of the next).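

In this assay, 4-(trifluoromethyl)phenyl in place of 2-methylphenyl on a carbonyl carbon gives a 1.7-fold higher number from compound 2 to compound 3 (0.24 log units; within the scatter) and so does not separate these two compounds, even though the entering group brings fluorine and has more heavy atoms than the group it replaces. The exchange of 2-iodophenyl for the same 4-(trifluoromethyl)phenyl gives a 4.2-fold higher number from compound 1 to compound 3 (0.63 log units; beyond the scatter) and, taken with the earlier step from the iodo compound, leaves compound 1 as the only one of the three set apart from both others, with the lowest number. The series now shows two different aryl exchanges away from 2-iodophenyl, both ending beyond the scatter, but nothing available accounts for the separation of compound 1 from the other two.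

The compounds shown leave open how an unsubstituted phenyl, or an aryl ring carrying an amine or a carboxylic acid, would read out on this carbonyl carbon, and whether iodo itself or the whole 2-iodophenyl group sets compound 1 apart. Going by these compounds, all three compounds also share the 2-chlorophenyl group, so what an exchange of that group would do remains unknown.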